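Chloro on the anilino ring of the bis-thioacetate series

The compounds below may be only part of what the source reports. "The series", "measured", "known", "first", "only" and "open" are said of these compounds alone.

Measured in a functional assay on Bel-7402 cells (Homo sapiens) for inhibition, read by MTT assay, with a stated time of 24 h, tested at 1 ug/mL (a lower number here means less inhibition of growth, a higher number more inhibition of growth at the concentration tested), so far:
- compound 1 `CC(=O)SCCC(CCCCC(=O)O)SC(C)=O` gives 12.8%
- compound 2 `O=C(CCCCC(S)CCS)Nc1ccc([N+](=O)[O-])c(C(F)(F)F)c1` gives 0.68%
- compound 3 `CC(=O)SCCC(CCCCC(=O)Nc1ccccc1)SC(C)=O` gives 2.84%

Compound 3 stands within the scatter of both compound 1 and compound 2, so no firm order can be drawn around it. The next compound is compound 4 `CC(=O)SCCC(CCCCC(=O)Nc1ccccc1Cl)SC(C)=O`, which carries chloro in place of hydrogen on an aromatic carbon, turning anilino into (2-chlorophenyl)amino. Going by the values given here, the counted difference is chloro in place of hydrogen on an aromatic carbon and it is the only change.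

Among the compounds with values here, no measured step makes this replacement on the ring. Within the data shown here, the one step available is a number 10 percentage points lower from compound 1 to compound 3 (within the scatter) and it concerns the carbonyl end, with anilino in place of hydroxy. Among the measured compounds shown here, it is the only guide to the size of a change. Compound 2 also carries a substituted aromatic ring, but it differs from compound 3 in more than one place, so no single step can be read from it. With this little evidence, no direction can be argued, and no step beyond the scatter is expected. The expected step is a number 1.2 percentage points higher from compound 3 to compound 4 (within the scatter) on this reading. For compound 4 the estimated value in this assay is 4%, with an expected range from 0% to 13%.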

Compound 4, percent growth inhibition at one concentration: 5.01%
Compound 4: middle estimate off by 1 percentage points, on the low side; the range from low to high includes it.
By their numbers in this assay, from the lowest: compounds 2, 3, 4 and 1 (each within the scatter of the next, the first and the last beyond it).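

In this assay, going by these compounds alone, chloro in place of hydrogen on an aromatic carbon, ortho to a large group, gives the first measured step on the ring of this series: a number 2.2 percentage points higher from compound 3 to compound 4 (within the scatter). This replacement at this position therefore leaves the read-out within the usual scatter at the single concentration tested, and anilino and (2-chlorophenyl)amino cannot be told apart here. The step at the carbonyl end, a number 7.8 percentage points lower from compound 1 to compound 4 (within the scatter), also stays within the scatter, so the free acid and this chloro-substituted amide are not separated either, and nothing measured on these compounds bears on what lies behind these small steps.

Going by these compounds, whether a group other than chloro on this ring, such as methoxy, nitrile or dimethylamino, would give a step beyond the scatter remains open, as does the outcome of moving chloro elsewhere on the ring. Compound 2 differs from compound 3 and compound 4 in more than one place, so its steps cannot be read, and the separate contributions of its ring substituents and its free thiol groups remain unresolved.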